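The source may hold more compounds than are shown below. What is called first, only, known or untested is meant among the compounds shown, and "the series" means these compounds.

Measured in an ADME assay on microsomes from liver (Canis lupus familiaris) for metabolic stability; a higher number here means that the compound lasts longer, a lower number that the compound disappears faster:
- compound 1 `N#Cc1ccc(-c2nc(NCCNc3ccc([N+](=O)[O-])c(N)n3)ncc2-c2ncc[nH]2)cc1`: > 0.5 h (a limit)
- compound 2 `Nc1nc(NCCNc2ncc(-c3ncc[nH]3)c(-c3ccc(F)cc3F)n2)ccc1[N+](=O)[O-]`: > 0.5 h (a limit)
- compound 3 `Nc1nc(NCCNc2ncc(-c3ncc[nH]3)c(-c3cc(F)ccc3Cl)n2)ccc1[N+](=O)[O-]`: > 0.5 h (a limit)

In this assay compound 3 gives > 0.5 h, which is a limit and not a number. Its standing in the series is set by the limit of > 0.5 h in this assay, at which 3 of the 3 values shown sit. No order can be drawn among the three compounds.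

The next step leads to compound 4 `Nc1nc(NCCNc2ncc(-c3ncc[nH]3)c(-c3cc(F)c(Cl)cc3F)n2)ccc1[N+](=O)[O-]`, with 4-chloro-2,5-difluorophenyl in place of 2-chloro-5-fluorophenyl on an aromatic carbon.

Within the data shown here, three measured steps bear on this change, all of them swaps of the phenyl group on the same aromatic carbon: a step that the two limits leave unreadable from compound 1 to compound 2, a step that the two limits leave unreadable from compound 1 to compound 3 and a step that the two limits leave unreadable from compound 2 to compound 3. None of them has a readable size, so the series gives no measured effect of such a swap and no direction for it.

Compound 4 is expected to be reported as a limit as well. The estimated change is a step that the limit leaves unreadable from compound 3 to compound 4, with no step beyond the usual scatter expected in either direction. For compound 4 the expected half-life is 0.7 h, with an estimated range of 0.4 h to 1.4 h.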

Compound 4, half-life: > 0.5 h
Compound 4 ended at the assay's limit (the forecaster's own chance of this, stated with the estimate: 85%); the middle value does not contradict the limit.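

In this assay compound 4 gives > 0.5 h, which is a limit and not a number. No step from compound 1, compound 2 or compound 3 to compound 4 can be read: the limit of > 0.5 h in this assay, at which 4 of the 4 values shown sit.

The compounds shown leave open how far apart the four half-lives lie and whether swapping the phenyl group on this aromatic carbon changes the half-life at all.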